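This account rests on a few compounds, and the source may have more. Where it says the series, first, only, none or still open, it means among the compounds named here.

Compound 3 `Nc1scc(-c2cccc(Br)c2)c1C(=O)c1ccccc1` gives 67% in a functional assay on CHO cells for agonist activity at adenosine receptor A1 (Homo sapiens), read by fluorescence and ERK phosphorylation, with stated times of 30 min and 1.5 h, tested at 3 uM (a lower number here means a weaker effect, a higher number a stronger effect of the compound at the concentration tested), the highest of the three numbers in hand. Compound 1 `Nc1scc(-c2ccccc2)c1C(=O)c1ccccc1` gives 49% in this assay, and compound 2 `Nc1scc(-c2cccc(Cl)c2)c1C(=O)c1ccccc1` gives 45%. The measured steps are a number 18 percentage points higher from compound 1 to compound 3 (beyond the scatter) and a number 22 percentage points higher from compound 2 to compound 3 (beyond the scatter), while a number 4 percentage points lower from compound 1 to compound 2 (within the scatter). Compound 4 `Nc1scc(-c2ccc(I)cc2)c1C(=O)c1ccccc1` has not yet been measured. It differs from compound 3 in one place: 4-iodophenyl in place of 3-bromophenyl on an aromatic carbon. None of the three measured steps covers this exact change. For the measured compounds named here, the bromo-for-hydrogen and bromo-for-chloro steps show that a single halogen on that phenyl ring can move the number by a modest amount, but an iodo group, and the 4-iodophenyl pattern, has no precedent among the measured compounds. A step in this assay no larger than those two, in either direction, is therefore expected, with a wide margin of doubt. Compound 4 is estimated at 55%, within 30% to 80%, which means an expected step of a number 12 percentage points lower from compound 3 to compound 4 (beyond the scatter).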

Compound 4, a percentage reported as activity, at one concentration (the size of the read-out at that concentration, not a potency): 51%
Compound 4: the middle estimate sits 4 percentage points above what was measured; measured number inside the range.
By their numbers in this assay, from the lowest: compounds 2, 1 and 4 (each within the scatter of the next); then compound 3.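

In this assay, for the compounds shown here, the swap of 3-bromophenyl for 4-iodophenyl gives a number 16 percentage points lower from compound 3 to compound 4 (beyond the scatter), so this position does not accept every single halogen-bearing phenyl alike, and compound 3 remains the one compound that stands clear of all the others. The iodo group leaves the read-out level with the unsubstituted phenyl, a number 2 percentage points higher from compound 1 to compound 4 (within the scatter), and with the chloro analogue, a number 6 percentage points higher from compound 2 to compound 4 (within the scatter), so among these four compounds a halogen on this ring does not by itself raise the number, with compound 3 as the sole exception. Nothing measured here gives a reason for these differences. On these data alone, the step from compound 3 changes both the halogen and its place on the ring at once, so which of the two matters stays open. As far as these compounds go, how a methoxy group or an amine on that phenyl ring would read is also open.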